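Iodophenyl Amine in Place of Cyclohexyl on a Shared Core

The source may hold more compounds than are shown below. What is called first, only, known or untested is meant among the compounds shown, and "the series" means these compounds.

Compound 1, `Cc1ccc(NC2=CC(=O)c3c(nc4n3[C@H]3OC[C@@H](O)[C@H]3OC4)C2=O)cc1C`: 4950 nM
Compound 2, `CCOc1ccccc1NC1=CC(=O)c2c(nc3n2[C@H]2OC[C@@H](O)[C@H]2OC3)C1=O`: a limit only, > 4000 nM
Compound 3, `O=C1C(NC2CCCCC2)=CC(=O)c2c1nc1n2[C@H]2OC[C@@H](O)[C@H]2OC1`: a limit only, > 16000 nM

Three compounds were measured in a functional assay on MCF7 cells (Homo sapiens) for inhibition, read by sulforhodamine B assay; a lower number here means a stronger inhibitor, a higher number a weaker inhibitor. Compound 1 gives a number, 4950 nM. For compound 2 the assay reports only a limit, > 4000 nM. For compound 3 likewise only a limit is known, > 16000 nM, so compound 3 stands at the weak end of what is shown, without a number of its own. Compound 4, `O=C1C(Nc2ccc(I)cc2)=CC(=O)c2c1nc1n2[C@H]2OC[C@@H](O)[C@H]2OC1`, differs from compound 3 in one place: 4-iodophenyl in place of cyclohexyl on an amine nitrogen. Of the measured steps, only an at least 3.2-fold higher number from compound 1 to compound 3 (0.50 log units; beyond the scatter) is readable; a step that the limit leaves unreadable from compound 1 to compound 2 and a step that the two limits leave unreadable from compound 2 to compound 3 cannot be sized. An aryl amine is expected to give a lower number than the cyclohexyl amine of compound 3 because in this assay compound 1 gives 4950 nM. The expected step is an at least 3.2-fold lower number from compound 3 to compound 4 (0.50 log units; beyond the scatter). Compound 4 is estimated at 5000 nM, between 1500 nM and 20000 nM.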

Compound 4, half-maximal inhibitory concentration: 3890 nM
Beside the measured number, compound 4's estimate is 1.3-fold (0.11 log units) above it; low and high end bracket the measured number.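

In this assay, 4-iodophenyl in place of cyclohexyl on the amine nitrogen gives an at least 4.1-fold lower number from compound 3 to compound 4 (0.61 log units; beyond the scatter), so a second aryl amine with a measured number now stands apart from the cyclohexyl amine. Against 3,4-dimethylphenyl the same position gives a 1.3-fold lower number from compound 1 to compound 4 (0.10 log units; within the scatter), so these two aryl groups are not told apart, and against 2-ethoxyphenyl it gives an at least 1.0-fold lower number from compound 2 to compound 4 (0.01 log units; that floor lies within the scatter). Compound 3 is known only as a limit: the limit of > 16000 nM in this assay, at which 1 of the 4 values shown sits.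

Going by these compounds, the true size of the step away from cyclohexyl therefore stays open. Also open, on these data alone, is whether an unsubstituted phenyl, a 4-fluorophenyl or a benzyl amine would stand at the same level.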